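This account rests on a few compounds, and the source may have more. Where it says the series, first, only, none or still open, it means among the compounds named here.

Compound 1 `Cc1ccsc1-c1cncc(Cl)c1N1CCC2(CCNC2=O)CC1` belongs to a small set built on a shared core. In a functional assay on MV4-11 cells (Homo sapiens) for inhibition, read by resazurin assay, with a stated time of 72 h (a higher number here means a weaker inhibitor of growth, a lower number a stronger inhibitor of growth), compound 1 gives 910 nM, the lowest of the three numbers. Among the compounds with values here, compound 2 `O=C1NCCC12CCN(c1c(Cl)cncc1-c1ccc(CN3CCCC3)s1)CC2` gives 3370 nM and compound 3 `O=C1NCCC12CCN(c1c(Cl)cncc1-c1ccc(CN3CCCCC3)s1)CC2` gives 4010 nM; the only step between measured compounds, a 1.2-fold higher number from compound 2 to compound 3 (0.08 log units; within the scatter), is a change on the thiophene ring that leaves the number essentially unchanged. Compound 4 `CC(=O)c1sccc1-c1cncc(Cl)c1N1CCC2(CCNC2=O)CC1` differs from compound 1 by 2-acetylthiophen-3-yl in place of 3-methylthiophen-2-yl on an aromatic carbon. Within the data shown here, no measured step reshapes this thiophene ring in the same way, so there is no direct guide; the one step that touches the thiophene stays within the scatter, which suggests a modest move at most. Compound 4 is therefore expected near 1500 nM, within 500 nM to 5000 nM, a step of a 1.6-fold higher number from compound 1 to compound 4 (0.22 log units; within the scatter) that is estimated, not measured.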

Compound 4, concentration for 50% growth inhibition: > 100000 nM
Compound 4: only a limit was reported; the forecaster's own chance of this, stated with the estimate: 5%; middle value at least 66-fold (1.82 log units) away from the limit.
By their numbers in this assay, from the lowest: compound 1; then compounds 2 and 3 (each within the scatter of the next). At a limit, above all of these: compound 4.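

Replacing 3-methylthiophen-2-yl with 2-acetylthiophen-3-yl on this aromatic carbon gives an at least 100-fold higher number from compound 1 to compound 4 (2.04 log units; beyond the scatter) in this assay. Compound 4 is reported only as a limit, not a number: the limit of > 100000 nM in this assay, at which 1 of the 4 values shown sits. Within the data shown here, the earlier compounds gave no sign of such sensitivity, as their one step, a 1.2-fold higher number from compound 2 to compound 3 (0.08 log units; within the scatter), changes a different place on the thiophene series. From the compounds shown here alone, this step changes both the acetyl group and the thiophene's point of attachment at once, so the share of each stays open. Going by these compounds, how an amine or a carboxylic acid in place of the acetyl would read also remains open.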